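Swapping the aryl group on the oxazole core for cytotoxicity

This account rests on a few compounds, and the source may have more. Where it says the series, first, only, none or still open, it means among the compounds named here.

Compound 1, `Cc1oc(-c2ccc(Cl)cc2)nc1CN1CCC(C(=O)NCCCN2C[C@H](C)C[C@H](C)C2)CC1`, was examined in an ADME assay on Huh7.5.1 cells (Homo sapiens) for cytotoxicity, read by ATP content, with a stated time of 48 h; a lower number here means that less compound is tolerated, a higher number that more compound is tolerated. In this assay compound 1 gives 11500 nM. Within the data shown here, the only comparison on hand is compound 2, `Cc1ccccc1-c1nc(CN2CCC(C(=O)NCCCN3CCCCC3)CC2)c(C)o1`, which in this assay gives 18100 nM; the two numbers lie within the scatter of each other, so neither can be set apart from the other.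

The next compound, compound 3, `CCc1ccccc1-c1nc(CN2CCC(C(=O)NCCCN3C[C@H](C)C[C@H](C)C3)CC2)c(C)o1`, differs from compound 1 in one place: 2-ethylphenyl in place of 4-chlorophenyl on an aromatic carbon. Among the measured compounds shown here, no step between measured compounds covers this change, and the numbers for compound 1 and compound 2 give no indication that exchanging one aryl group for another moves cytotoxicity beyond the scatter. Compound 3 is therefore expected to show no step beyond the scatter, with a 1.1-fold higher number from compound 1 to compound 3 (0.05 log units; within the scatter) as the estimate. The expected value for compound 3 in this assay is 13000 nM, within a range from 6000 nM to 30000 nM.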

Compound 3, half-maximal cytotoxic concentration: 9320 nM
The estimate for compound 3 lay 1.4-fold (0.14 log units) above the measured number; the range from low to high includes it.
By their numbers in this assay, from the lowest: compounds 3, 1 and 2 (each within the scatter of the next).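

In this assay, among these compounds, the exchange of 4-chlorophenyl for 2-ethylphenyl gives a 1.2-fold lower number from compound 1 to compound 3 (0.09 log units; within the scatter) and provides the first pair that differs only at this position. On this aromatic carbon, next to the ring nitrogen and next to the ring oxygen, the two aryl groups cannot be set apart by this read-out, even though chlorine leaves and an ethyl group enters. No measurement at hand bears on a cause for this result.

From the compounds shown here alone, whether a phenyl group carrying an amine or a carboxylic acid, or a pyridine ring in place of the phenyl ring, would move the number beyond the scatter remains open. Also open, going by these compounds, is whether a longer chain between the amide and the terminal amine would do so.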